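Lengthening a chain: from compound 3 to compound 4

This account rests on a few compounds, and the source may have more. Where it says the series, first, only, none or still open, it means among the compounds named here.

Measured so far:
compound 1 `C=CCCC(=O)N1CC(CC=C)C1=O` gives 96.5% in an assay for inhibition of Fatty-acid amide hydrolase 1 (Homo sapiens), tested at 1 mM; a lower number here means less inhibition, a higher number more inhibition at the concentration tested (going by the name of the read-out);
compound 2 `C=CCCC1CNC1=O` gives 48% in this assay;
compound 3 `C=CCCC(=O)N1CC(CCC=C)C1=O` gives 103% in this assay.

Compound 3 holds the highest of the three numbers, with compound 1 close by, within the scatter, and compound 2 far lower, beyond the scatter. Compound 4 `C=CCCCC1CN(C(=O)CCC=C)C1=O` differs from compound 3 in one place: allyl in place of vinyl on a saturated chain carbon, two bonds along the chain from a saturated ring carbon. Going by the values given here, one measured step bears on this change, the same kind of exchange at another place in the chain: a number 6.5 percentage points higher from compound 1 to compound 3 (within the scatter). Since that step stayed within the scatter at already high inhibition, the expected step in this assay is a number 3 percentage points lower from compound 3 to compound 4 (within the scatter), none beyond the scatter. Compound 4 is therefore estimated at 100%, with an expected range from 88% to 108%.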

Compound 4, a percentage reported as inhibition, at one concentration (the size of the read-out at that concentration, not a potency): 101%
Compound 4: middle estimate off by 1 percentage points, on the low side; the measured number falls inside the stated range.
By their numbers in this assay, from the lowest: compound 2; then compounds 1, 4 and 3 (each within the scatter of the next).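

In this assay, lengthening the chain from but-3-en-1-yl to pent-4-en-1-yl at this position leaves the number level (a number 2 percentage points lower from compound 3 to compound 4 (within the scatter)). The longer exchange from allyl to pent-4-en-1-yl also stays level (a number 4.5 percentage points higher from compound 1 to compound 4 (within the scatter)), so these three chains cannot be told apart at this concentration. The data shown give no explanation for this.

Going by these compounds, whether a still longer chain would keep this level remains open. So does whether a chain ending in an amine or a carboxylic acid, rather than the double bond, would do so.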